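The source may hold more compounds than are shown below. What is called first, only, known or untested is meant among the compounds shown, and "the series" means these compounds.

Three compounds share one core and were tested in a functional assay on SF-295 cells (Homo sapiens) for inhibition, read by sulforhodamine B assay, with a stated time of 48 h, tested at 10 uM; a higher number here means more inhibition of growth at the concentration tested, a lower number less inhibition of growth. Compound 1 `CC(=O)c1cccc(Nc2ccnc(SCC(=O)c3ccc(C(F)(F)F)cc3)n2)c1`, compound 2 `CCOC(=O)c1ccc(Nc2ccnc(SCC(=O)c3ccc([N+](=O)[O-])cc3)n2)cc1` and compound 3 `CC(=O)c1ccc(Nc2ccnc(SCC(=O)c3ccc(Cl)cc3)n2)cc1` all carry a thioether-linked ketone on that core. In this assay compound 2 gives 28%, the highest of the three numbers. Compound 1 gives 15% and compound 3 gives 14%, each a gap beyond the usual scatter below compound 2. Compound 4 `CCOC(=O)c1ccc(Nc2ccnc(SCC(=O)c3ccc(C#N)cc3)n2)cc1` has not yet been measured. Within the data shown here, it differs from compound 2 in one place: cyano in place of nitro on an aromatic carbon No measured pair shows what this swap does, so the direction is uncertain; a small step is expected, a number 6 percentage points lower from compound 2 to compound 4 (within the scatter), not clearly beyond the scatter. In this assay compound 4 is expected to give about 22%, estimated between 8% and 38%.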

Compound 4, percent growth inhibition at one concentration: 24%
For compound 4 the middle estimate is 2 percentage points below the measured one; the measured number falls inside the stated range.
By their numbers in this assay, from the lowest: compounds 3, 1, 4 and 2 (each within the scatter of the next, the first and the last beyond it).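

Putting cyano in place of nitro on the aromatic carbon para to a large group gives a number 4 percentage points lower from compound 2 to compound 4 (within the scatter) in this assay. Among these compounds, this is the first pair here that differs in one place only, and it shows that at this position the two groups cannot be told apart in this test. Nothing measured here bears on the reason for this result. On these data alone, whether an amine or a carboxylic acid at the same position would also read like compound 4 remains open. So does whether this swap behaves alike on other compounds sharing the core.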